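The source may hold more compounds than are shown below. What is called first, only, known or untested is meant among the compounds shown, and "the series" means these compounds.

Measured compounds: compound 1, `O=C(Nc1cccc(C(F)(F)F)c1)c1nsnc1O`, with -1.1% in an assay on isolated protein for inhibition of mitogen-activated protein kinase kinase kinase 14 (Homo sapiens), read by ADP-Glo, with a stated time of 60 min, tested at 100 uM, in the presence of a further agent that is not named here; on this read-out higher numbers stand for more inhibition at the one concentration tested (going by the name of the read-out) and lower numbers for less inhibition; compound 2, `O=C(Nc1cc(C(F)(F)F)cc(C(F)(F)F)c1)c1nonc1O`, with 19.3% in this assay.

Of the two numbers in hand, compound 2 stands highest: its nearest neighbour is compound 1, whose number is lower by a gap that lies beyond the usual scatter. Within the data shown here, compound 1 and compound 2 differ in more than one place, so no single step between them is counted; their two values show only that compound 2 gives more inhibition in this assay than compound 1 does.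

The unmeasured compound 3, `O=C(Nc1cccc(C(F)(F)F)c1)c1nonc1O`, is reached from compound 2 by one change: hydrogen in place of trifluoromethyl on an aromatic carbon. Among the measured compounds shown here, no step of this kind stands among the measured pairs, so the expectation must rest on the two values alone. Since compound 1, which also carries a single trifluoromethyl group, gives -1.1%, the step of a number 11.3 percentage points lower from compound 2 to compound 3 (beyond the scatter) is expected to be a decrease, about the size of the scatter. Compound 3 is therefore expected to give 8% in this assay, with a range from -8% to 22%.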

Compound 3, a percentage reported as inhibition, at one concentration (the size of the read-out at that concentration, not a potency): 11.8%
For compound 3 the middle estimate is 3.8 percentage points below the measured one; measured number inside the range.
By their numbers in this assay, from the lowest: compound 1; then compounds 3 and 2 (each within the scatter of the next).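

In this assay, hydrogen in place of trifluoromethyl on the aromatic carbon gives a number 7.5 percentage points lower from compound 2 to compound 3 (within the scatter), so at this position the second trifluoromethyl group has no effect that can be told apart from the scatter of repeated measurements. Among these compounds, the exchange of the five-membered aromatic ring on the carbonyl carbon, with the sulfur-bearing group replaced by the group without sulfur, gives a number 12.9 percentage points higher from compound 1 to compound 3 (beyond the scatter), which is a modest step but beyond the scatter, so of the two places in which compound 1 and compound 2 differ, only this exchange has a step that stands clear of it. Nothing in hand says why either step has the size it has.

As far as these compounds go, it remains open whether another group on that aromatic carbon, such as an amine, a carboxylic acid or a methoxy group, would move the number beyond the scatter, and whether the two changes add up when the sulfur-bearing ring is paired with both trifluoromethyl groups. These are also readings at a single concentration, so they leave open how any of the three compounds would rank by potency.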